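The compounds below may be only part of what the source reports. "The series", "measured", "known", "first", "only" and "open" are said of these compounds alone.

Measured in an ADME assay on BJ cells (Homo sapiens) for cytotoxicity, read by luminescence, with a stated time of 72 h; on this read-out higher numbers stand for an effect only at larger amounts of compound and lower numbers for an effect already at smaller amounts:
- compound 1 `CCOC(=O)c1c(-c2cccc(OC)c2)[nH]c2cc(OC)ccc2c1=O`: > 21500 nM
- compound 2 `CCOC(=O)c1c(-c2cccc(OC)c2)[nH]c2cc(OC(C)C)ccc2c1=O`: > 21500 nM

Compound 1 has no exact number, only a limit: > 21500 nM. Compound 2 shares it, as shown by the limit of > 21500 nM in this assay, at which 2 of the 2 values shown sit. Among the measured compounds shown here, the one measured step, a step that the two limits leave unreadable from compound 1 to compound 2, therefore offers no size to carry over.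

Compound 3 `CCOC(=O)c1c(-c2cccc(OC)c2)[nH]c2cc(OC)c(OC)cc2c1=O` has not yet been measured. It differs from compound 1 by methoxy in place of hydrogen on an aromatic carbon, a methoxy in place of hydrogen on an aromatic carbon. With no readable step to suggest a direction, no shift beyond the usual scatter is expected in this assay. The expected step is a step that the limit leaves unreadable from compound 1 to compound 3. Compound 3 is estimated at 25000 nM, within an expected range of 12000 nM to 50000 nM, and will quite likely be reported only as a limit.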

Compound 3, half-maximal effective concentration: > 21500 nM
Compound 3: a limit, no number; the forecaster's own chance of this, stated with the estimate: 80%; the middle value is on the limit's open side.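

In this assay, among the compounds shown here, compound 1 and compound 3 both give only limits, not numbers, so no step between them can be read: the limit of > 21500 nM in this assay, at which 3 of the 3 values shown sit. The compounds shown leave open the concentration at which any of them would reach a half-maximal effect, and whether the added methoxy changes it.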